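Swapping chloro for bromo on the aryl amine

The source may hold more compounds than are shown below. What is called first, only, known or untested is meant among the compounds shown, and "the series" means these compounds.

Compound 1, `CC(=O)OC[C@H]1O[C@@H](SC(=S)C2=C(Nc3ccc(Cl)cc3Cl)CC(C)(C)CC2=O)[C@H](OC(C)=O)[C@@H](OC(C)=O)[C@@H]1OC(C)=O`, compound 2, `CC(=O)OC[C@H]1O[C@@H](SC(=S)C2=C(Nc3ccc(Cl)cc3)CC(C)(C)CC2=O)[C@H](OC(C)=O)[C@@H](OC(C)=O)[C@@H]1OC(C)=O`, and compound 3, `CCCCSC(=S)C1=C(Nc2ccc(Br)cc2)CC(C)(C)CC1=O`, were all tested in a functional assay on PBMC cells (Homo sapiens) for inhibition, read by ELISA, with a stated time of 18 h; on this read-out higher numbers stand for weaker inhibition and lower numbers for stronger inhibition. Compound 1 reaches only the limit of this assay, > 20 ug/mL. Compound 3 likewise gives only a limit, > 20 ug/mL. Compound 2 gives 3.5 ug/mL, which makes it the only one of the three with a true number; the other two values sit at the limit of > 20 ug/mL in this assay, at which 2 of the 3 values shown sit. For the measured compounds named here, the single measured step, an at least 5.7-fold lower number from compound 1 to compound 2 (0.75 log units; beyond the scatter), shows that hydrogen in place of chloro on an aromatic carbon strengthens inhibition by at least a modest amount.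

Compound 4, `CC(=O)OC[C@H]1O[C@@H](SC(=S)C2=C(Nc3ccc(Br)cc3)CC(C)(C)CC2=O)[C@H](OC(C)=O)[C@@H](OC(C)=O)[C@@H]1OC(C)=O`, differs from compound 2 by bromo in place of chloro on an aromatic carbon. Going by the values given here, no measured step exchanges one halogen for another, so the step from compound 1 to compound 2 does not speak directly to this change. Compound 3 carries the same bromo group on its aryl amine, but on a different sulfur side chain, and its value in this assay is a limit rather than a number, so it gives no usable comparison with compound 4. For compound 4 the step of a 1.1-fold higher number from compound 2 to compound 4 (0.06 log units; within the scatter) is therefore expected to stay within the scatter of this assay. Compound 4 is estimated at 4 ug/mL, with a range from 1.5 ug/mL to 12 ug/mL.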

Compound 4, half-maximal inhibitory concentration: 3.4 ug/mL
Compound 4: middle estimate off by 1.2-fold (0.07 log units), on the high side; low and high end bracket the measured number.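

In this assay, bromo and chloro at this place on the ring cannot be told apart: a 1.0-fold lower number from compound 2 to compound 4 (0.01 log units; within the scatter). The second step, an at least 5.8-fold lower number from compound 1 to compound 4 (0.76 log units; beyond the scatter), shows that the 4-bromophenyl group, like the 4-chlorophenyl group of compound 2, is clearly stronger than the 2,4-dichlorophenyl group, so this gain does not depend on which of these two halogens is present. The true size of that step stays unknown, since the value of compound 1 is only a limit: the limit of > 20 ug/mL in this assay, at which 2 of the 4 values shown sit.

As far as these compounds go, it remains open whether a halogen is needed here at all, and a plain phenyl group or a 4-methoxyphenyl or 4-aminophenyl group on the amine nitrogen would test this directly. Compound 3, which also carries the 4-bromophenyl group but has a different side chain on sulfur, gives > 20 ug/mL, which is a limit, so what that side chain adds to inhibition also remains an open question.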